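This account rests on a few compounds, and the source may have more. Where it says the series, first, only, none or still open, it means among the compounds named here.

Measured so far:
compound 1 `CC(C(=O)NCc1ccc(C(F)(F)F)nc1NC1CCCCC1)c1ccc(NS(C)(=O)=O)c(F)c1` — 260 nM
compound 2 `CC(C(=O)NCc1ccc(C(F)(F)F)nc1Nc1ccccc1)c1ccc(NS(C)(=O)=O)c(F)c1` — 1400 nM
compound 3 `CC(C(=O)NCc1ccc(C(F)(F)F)nc1N1CCC(c2ccccc2)CC1)c1ccc(NS(C)(=O)=O)c(F)c1` — 25 nM

In a functional assay on CHO-K1 cells for antagonist activity at transient receptor potential cation channel subfamily V member 1 (Homo sapiens), read by FLIPR (a lower number here means a stronger inhibitor, a higher number a weaker inhibitor), compound 3 gives the lowest number of the three; compound 1 sits at a 10-fold lower number from compound 1 to compound 3 (1.02 log units; beyond the scatter) and compound 2 at a 56-fold lower number from compound 2 to compound 3 (1.75 log units; beyond the scatter), both steps beyond the scatter.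

Compound 4 `COC1CCN(c2nc(C(F)(F)F)ccc2CNC(=O)C(C)c2ccc(NS(C)(=O)=O)c(F)c2)CC1` is not yet measured. It differs from compound 3 in one place: methoxy in place of phenyl on a saturated ring carbon.

Among the compounds with values here, no measured step exchanges a group on the piperidine itself. The steps that bear indirectly are a 10-fold lower number from compound 1 to compound 3 (1.02 log units; beyond the scatter) and a 56-fold lower number from compound 2 to compound 3 (1.75 log units; beyond the scatter), which show the 4-phenylpiperidin-1-yl group set well apart from smaller amine substituents. Removing the phenyl for methoxy is therefore expected to move the number upward, beyond the scatter but short of the largest step seen. For compound 4 the expected step is a 6.0-fold higher number from compound 3 to compound 4 (0.78 log units; beyond the scatter). The estimate for compound 4 in this assay is 150 nM, with a range from 40 nM to 600 nM.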

Compound 4, half-maximal inhibitory concentration: 280 nM
Estimate against measurement, compound 4: 1.9-fold (0.27 log units) below; the range from low to high includes it.
By their numbers in this assay, from the lowest: compound 3; then compounds 1 and 4 (each within the scatter of the next); then compound 2.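

In this assay, methoxy in place of phenyl on the saturated ring carbon gives an 11-fold higher number from compound 3 to compound 4 (1.05 log units; beyond the scatter), so the piperidine ring alone does not keep the level of compound 3. The 4-methoxypiperidin-1-yl group shows a 1.1-fold higher number from compound 1 to compound 4 (0.03 log units; within the scatter), within the scatter, and a 5.0-fold lower number from compound 2 to compound 4 (0.70 log units; beyond the scatter), beyond it. No measured evidence explains these steps.

Phenyl and methoxy differ in more than one feature, so the compounds shown do not separate ring from oxygen. From the compounds shown here alone, a cyclohexyl, benzyl or hydroxyl group on that carbon remains open.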